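Swapping Nitro for Bromo in an Endothelin Receptor Series

A few compounds are considered here, and "the series" means these few. Any claim that something is new, unique, unknown or untested is made for them only; others in the source may bear on it.

Measured so far:
compound 1 `O=[N+]([O-])c1ccc(OCc2ccsc2)cc1/C=C(/CO)c1ccccc1Cl` gives 400 nM
compound 2 `O=[N+]([O-])c1ccc(OCc2ccsc2)cc1/C=C(/CO)c1ccccc1` gives 1400 nM

Both numbers come from an assay on A10 cells for binding affinity to Endothelin-1 receptor (Rattus norvegicus); a lower number here means a stronger inhibitor, a higher number a weaker inhibitor. For the measured compounds named here, compound 2 stands highest of the two; its nearest neighbour is compound 1, and the one measured step, a 3.5-fold higher number from compound 1 to compound 2 (0.54 log units; beyond the scatter), shows a modest loss when a chloro is replaced by hydrogen on an aromatic carbon.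

Compound 3 `OC/C(=C/c1cc(OCc2ccsc2)ccc1Br)c1ccccc1` differs from compound 2 by bromo in place of nitro on an aromatic carbon. Going by the values given here, the only step measured so far concerns a different ring and a different kind of group, so it offers no direct guide to this change; it shows merely that a single substituent change can shift the number modestly. A step of similar size, in either direction, is therefore plausible, and the expectation is written as a 1.8-fold higher number from compound 2 to compound 3 (0.25 log units; within the scatter). Compound 3 is estimated at 2500 nM, within a range from 600 nM to 10000 nM.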

Compound 3, half-maximal inhibitory concentration: 2100 nM
Beside the measured number, compound 3's estimate is 1.2-fold (0.08 log units) above it; the measured number falls inside the stated range.
By their numbers in this assay, from the lowest: compound 1; then compounds 2 and 3 (each within the scatter of the next).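

In this assay, for the compounds shown here, this is the first measured change at the position para to the (thiophen-3-yl)methoxy group: bromo in place of nitro gives a 1.5-fold higher number from compound 2 to compound 3 (0.18 log units; within the scatter) and so does not separate the two compounds. The groups differ in what is counted on them, with nitro holding 3 heavy atoms and 2 hydrogen-bond acceptors and bromo holding 1 heavy atom and 0 hydrogen-bond acceptors, yet the two numbers lie within the scatter of each other. No measurement at hand accounts for this result.

Only nitro and bromo are shown at this position, so it remains open how an amine or a carboxylic acid would read there. Also open, on these data alone, is whether adding the chloro that separates compound 1 from compound 2 would give a similar step on compound 3.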